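A few compounds are considered here, and "the series" means these few. Any claim that something is new, unique, unknown or untested is made for them only; others in the source may bear on it.

Compound 2 `Cc1ccccc1COc1ccccc1C(=O)Nc1cccnc1` gives 1500 nM in an assay on lysate for inhibition of phosphatidylcholine:ceramide cholinephosphotransferase 2 (Homo sapiens), read by HPLC, with stated times of 30 min and 2 h (a lower number here means a stronger inhibitor, a higher number a weaker inhibitor), the lowest of the two numbers reported there. Compound 3 `O=C(Nc1cccnc1)c1ccccc1OCc1ccccc1C(F)(F)F` gives 2100 nM in this assay, and the step of a 1.4-fold higher number from compound 2 to compound 3 (0.15 log units; within the scatter) came from putting trifluoromethyl in place of methyl on an aromatic carbon. Compound 1 `O=C(NC1CCCNC1)c1ccccc1OCc1ccccc1Cl` gives > 100000 nM in this assay, which is a limit and not a number (the limit of > 100000 nM in this assay, at which 1 of the 3 values shown sits). Compound 4 `O=C(Nc1cccnc1)c1ccccc1OCc1c(F)cccc1Cl` differs from compound 2 by 2-chloro-6-fluorophenyl in place of 2-methylphenyl on a saturated chain carbon bound to an oxygen on an aromatic ring. Among the measured compounds shown here, the only measured step that bears on this change is the one from compound 2 to compound 3, which altered the same part of the structure and stayed within the scatter, so no step beyond the scatter is expected. The step of no change at the digits printed from compound 2 to compound 4 (within the scatter) is therefore expected to be small. Compound 4 is estimated at 1500 nM, between 500 nM and 5000 nM.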

Compound 4, half-maximal inhibitory concentration: 1500 nM
Beside the measured number, compound 4's estimate shows no gap at the digits printed; measured number inside the range.
By their numbers in this assay, from the lowest: compounds 2, 4 and 3 (each within the scatter of the next). At a limit, above all of these: compound 1.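

Putting 2-chloro-6-fluorophenyl in place of 2-methylphenyl gives no change at the digits printed from compound 2 to compound 4 (within the scatter) in this assay. The earlier step at this part of the structure replaced only methyl, whereas this one puts chlorine and fluorine on the ring together, and the number still holds. No measured property bears on why this change leaves the number where it stands. Still open, as far as these compounds go, is whether a carboxylic acid or an amine on this ring would move the number beyond the scatter. From the compounds shown here alone, a longer chain in place of the saturated chain carbon also remains untested here.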